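The compounds below may be only part of what the source reports. "The series", "measured", "known", "first", "only" and "open" are said of these compounds alone.

Of the compounds shown here, three built on one shared core have been tested in an assay for binding affinity to E3 ubiquitin-protein ligase Mdm2 (Homo sapiens), read by fluorescence polarization, with a stated time of 15 min; on this read-out higher numbers stand for weaker inhibition and lower numbers for stronger inhibition. Compound 1, `CCOC(=O)c1[nH]c2cc(Cl)ccc2c1C(NCC1CCCCC1)c1nnnn1-c1ccc(Cl)cc1`, gives 117000 nM in this assay, and it is the only one of the three with a number attached. Compound 2, `CCCCCNC(c1c(C(=O)OCC)[nH]c2cc(Cl)ccc12)c1nnnn1-c1ccc(Cl)cc1`, was reported in this assay as "not active" (no number reported), with no number given. Compound 3, `CCOC(=O)c1[nH]c2cc(Cl)ccc2c1C(NCC1CCCCC1)c1nnnn1-c1ccc(OCc2c(Cl)cccc2Cl)cc1`, was likewise reported as "not active" (no number reported), again without a number. For the measured compounds named here, compound 1 therefore stands as the single measured value, and that value marks only weak binding.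

Compound 4, `CCOC(=O)c1[nH]c2cc(Cl)ccc2c1C(NCC1CCCCC1)c1nnnn1-c1ccc(F)c(Cl)c1`, has not yet been measured in this assay. It differs from compound 1 in one spot: 3-chloro-4-fluorophenyl in place of 4-chlorophenyl on an aromatic nitrogen. Going by the values given here, no measured pair in this set shows what such a change does, so the expected step from compound 1 to compound 4 rests on the change alone. Since compound 1 already sits at 117000 nM, the expected step is small, within the usual scatter, with no clear direction; a slide to no reportable number, as happened for compound 2 and compound 3, is also a real possibility. The estimate for compound 4 is 130000 nM, with a range from 50000 nM to 400000 nM, which means an expected step of a 1.1-fold higher number from compound 1 to compound 4 (0.05 log units; within the scatter).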

Compound 4, inhibition constant: "not active" (no number reported)
For compound 4 the study gives words and no number; no gap can be computed for the estimate.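

For the compounds shown here, compound 4 was reported as "not active" in this assay with no number, so no step from compound 1 to compound 4 can be read. Nothing shown here explains this result. The compounds shown leave open how 3-chloro-4-fluorophenyl compares numerically with 4-chlorophenyl, and whether compound 2, compound 3 and compound 4 keep any measurable binding.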